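Three Phenols Measured, a Fourth Awaiting Its Number

This account rests on a few compounds, and the source may have more. Where it says the series, first, only, none or still open, it means among the compounds named here.

compound 1, `CCCCCCCCC(=O)NCc1cccc(OC)c1`: > 100000 nM
compound 2, `CCCCCCCCC(=O)NCc1ccc(O)c(O)c1`: 630 nM
compound 3, `CCCCCCCCC(=O)NCc1cc(O)cc(OC)c1`: > 100000 nM

All three were tested in a functional assay with Rattus norvegicus as the target; on this read-out higher numbers stand for an effect only at larger amounts of compound and lower numbers for an effect already at smaller amounts. For compound 1 the read-out is a limit of the assay, > 100000 nM. For compound 3 the read-out is likewise a limit, > 100000 nM. For the measured compounds named here, compound 2 gives 630 nM, the only number among the three. The change from compound 1 to compound 3 is hydroxy in place of hydrogen on an aromatic carbon; the step that the two limits leave unreadable from compound 1 to compound 3 cannot be sized because of the limit of > 100000 nM in this assay, at which 2 of the 3 values shown sit. How the core of compound 2 differs from that of compound 1 is not broken down here.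

Compound 4, `CCCCCCCCC(=O)NCc1ccc(O)c(O)c1O`, has not yet been measured. It arises from compound 2 by hydroxy in place of hydrogen on an aromatic carbon. This is the same kind of change as that from compound 1 to compound 3, but its surroundings differ: in compound 3 the entering hydroxy sits meta to a large group and meta to a methoxy group, whereas in compound 4 it sits ortho to a hydroxy group, ortho to a large group and meta to a hydroxy group. Going by the values given here, the one measured instance of this change gives no readable size, so it offers no guide. The expectation for compound 4 rests on compound 2, which gives 630 nM in this assay. The step of a 2.4-fold higher number from compound 2 to compound 4 (0.38 log units; beyond the scatter) is expected to be small. Compound 4 is estimated at 1500 nM, with a likely range from 300 nM to 10000 nM.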

Compound 4, half-maximal effective concentration: 7640 nM
The estimate for compound 4 lay 5.1-fold (0.71 log units) below the measured number; the measured number falls inside the stated range.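

In this assay, hydroxy in place of hydrogen on an aromatic carbon, ortho to a hydroxy group, ortho to a large group and meta to a hydroxy group, gives a 12-fold higher number from compound 2 to compound 4 (1.08 log units; beyond the scatter), so on the core of compound 2 this change moves the number a long way towards larger amounts of compound. For the compounds shown here, the same kind of change on the core of compound 1, which leads to compound 3, cannot be read because both of those compounds give a limit of the assay rather than a number: the limit of > 100000 nM in this assay, at which 2 of the 4 values shown sit. The series therefore holds only one sized instance of this change, which shows what it does in one setting but not whether that size carries over to another core, and the two instances also differ in what surrounds the entering hydroxy.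

The compounds shown leave open how the read-out would respond if an amine or a carboxylic acid stood in place of the entering hydroxy on the core of compound 2. They also leave open whether the step seen here would keep its size with a longer chain on the carbonyl.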